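The source may report more compounds than this note shows. Statements on the series, on what has been measured and on what is new or still open speak of the compounds shown alone.

The measured compounds:
Compound 1, `Cc1ccccc1-c1nn(-c2cccc(Cl)c2)cc1CNCCN1CCN(C)CC1`, gives 16000 nM in an ADME assay on Huh-7 cells (Homo sapiens) for cytotoxicity; on this read-out lower numbers stand for higher toxicity in this test and higher numbers for lower toxicity in this test.
Compound 2, `CCCN1CCC(CNCc2cn(-c3ccc([N+](=O)[O-])cc3)nc2-c2ccc(OC(F)(F)F)cc2)CC1`, gives 18000 nM in this assay.

These two numbers lie within the usual scatter of each other, so nothing separates compound 1 from compound 2 in this assay; both sit at the same level of toxicity toward these liver-derived cells. The unmeasured compound 3, `Cc1ccccc1-c1nn(-c2cc(F)ccc2F)cc1CNCCN1CCN(C)CC1`, shares its core with compound 1 and differs from it in one place: 2,5-difluorophenyl in place of 3-chlorophenyl on an aromatic nitrogen. Among the measured compounds shown here, no pair of measured compounds that differ in a single place is available, so the weight of this kind of change cannot be read from the data; two rather different measured compounds give the same level. On that basis the step from compound 1 to compound 3 is expected to be small, no change at the digits printed from compound 1 to compound 3 (within the scatter), in no firm direction and not beyond the scatter. Compound 3 is therefore estimated at 16000 nM in this assay, with a range from 7000 nM to 35000 nM.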

Compound 3, half-maximal cytotoxic concentration: > 20000 nM
Compound 3 gave a limit, no number (the forecaster's own chance of this, stated with the estimate: 10%); middle value at least 1.2-fold (0.09 log units) from the limit.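

In this assay compound 3 gives > 20000 nM, which is a limit of the assay and not a number. Among the compounds shown here, this is the first comparison here between compounds that differ in one place, and putting 2,5-difluorophenyl in place of 3-chlorophenyl on the aromatic nitrogen gives an at least 1.2-fold higher number from compound 1 to compound 3 (0.09 log units; that floor lies within the scatter). The change therefore brings no sign of greater toxicity in this test, but the true size of the step remains hidden, and the reading rests on a single capped value: the limit of > 20000 nM in this assay, at which 1 of the 3 values shown sits.

Still open, as far as these compounds go, is how this position would respond to a phenyl ring with a single fluorine, a methoxy group, a nitrile or a carboxylic acid. It is also unknown whether the same swap would give a similar result on the different amine side chain of compound 2.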